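Removing one chloro from a dichlorinated oxindole core

The source may hold more compounds than are shown below. What is called first, only, known or untested is meant among the compounds shown, and "the series" means these compounds.

Of the compounds shown here, two have been measured in an assay on CHO cells for displacement of a labelled ligand from 5-hydroxytryptamine receptor 7 (Homo sapiens); on this read-out higher numbers stand for weaker inhibition and lower numbers for stronger inhibition. Compound 1, `CCC1(CCCCN2CCN(c3cccc(Cl)c3)CC2)C(=O)Nc2ccccc21`, carries no substituent on the benzo ring of its core and gives 0.41 nM. Compound 2, `CCC1(CCCCN2CCN(c3cccc(Cl)c3)CC2)C(=O)Nc2c(Cl)cc(Cl)cc21`, carries chloro groups on that ring; in this assay compound 2 gives 9.46 nM, the highest number of the two and well beyond the scatter from compound 1.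

Compound 3, `CCC1(CCCCN2CCN(c3cccc(Cl)c3)CC2)C(=O)Nc2ccc(Cl)cc21`, differs from compound 2 in one place: hydrogen in place of chloro on an aromatic carbon, the change leaving a hydrogen meta to a chloro group and ortho to a fused ring. Within the data shown here, no measured pair shows exactly this step, so its size is an expectation only. Since compound 1 without chloro gives 0.41 nM and compound 2 with chloro groups gives 9.46 nM, taking one chloro away is expected to move the number downward, toward compound 1 but not all the way. The expected step from compound 2 to compound 3 is a 4.3-fold lower number from compound 2 to compound 3 (0.63 log units; beyond the scatter). Compound 3 is therefore estimated at 2.2 nM, within a range of 0.6 nM to 7 nM.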

Compound 3, inhibition constant: 8.27 nM
Estimate against measurement, compound 3: 3.8-fold (0.58 log units) below; measured number above the stated range.
By their numbers in this assay, from the lowest: compound 1; then compounds 3 and 2 (each within the scatter of the next).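

In this assay, replacing the chloro ortho to a fused ring and meta to a chloro group with hydrogen gives a 1.1-fold lower number from compound 2 to compound 3 (0.06 log units; within the scatter) and stays within the scatter, so on this read-out chloro and hydrogen at this position cannot be told apart. The large step in this set comes from the chloro that compound 3 keeps: placing it on the core of compound 1 gives a 20-fold higher number from compound 1 to compound 3 (1.30 log units; beyond the scatter). No measurement is available here to explain either result.

Going by these compounds, whether a methyl, methoxy or fluoro group at the same position would also read like hydrogen and chloro remains open. So does whether a fluoro or methyl group in place of the chloro kept by compound 3 would carry the same large step.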